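From tert-butyl to trifluoromethyl at low stability

The source may hold more compounds than are shown below. What is called first, only, known or untested is meant among the compounds shown, and "the series" means these compounds.

Compound 1 (`CCC(=O)c1ccccc1OC(=O)c1coc(-c2ccccc2)n1`) and compound 2 (`CC(C)(C)c1ccccc1OC(=O)c1coc(-c2ccccc2)n1`) share one core and differ in a single group. In an ADME assay on microsomes from liver (Rattus norvegicus, strain Sprague-Dawley) for metabolic stability, read by LC-MS, with a stated time of 15 min, tested at 20 uM (on this read-out higher numbers stand for a more stable compound and lower numbers for a less stable compound), compound 1 gives 8.7% and compound 2 gives 6.9% remaining, two values within the usual scatter of each other and both low on this scale. The next structure, compound 3 (`O=C(Oc1ccccc1C(F)(F)F)c1coc(-c2ccccc2)n1`), carries trifluoromethyl in place of tert-butyl on an aromatic carbon. Within the data shown here, the one measured step that bears on this is a number 1.8 percentage points lower from compound 1 to compound 2 (within the scatter) and it involves tert-butyl in place of propanoyl on an aromatic carbon. Among the measured compounds shown here, that single small step is thin evidence, and no trifluoromethyl compound has been measured yet, so no change beyond the scatter is expected in this assay here. The expected step is a number 1.1 percentage points higher from compound 2 to compound 3 (within the scatter) and it stays within the scatter. For compound 3 the estimated value is 8% with an expected range from 2% to 20% on this read-out.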

Compound 3, percent of the compound remaining: 10.7%
Compound 3: middle estimate off by 2.7 percentage points, on the low side; the measured number falls inside the stated range.
By their numbers in this assay, from the lowest: compounds 2, 1 and 3 (each within the scatter of the next).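

Placing trifluoromethyl on this aromatic carbon instead of tert-butyl gives a number 3.8 percentage points higher from compound 2 to compound 3 (within the scatter) and placing it there instead of propanoyl gives a number 2 percentage points higher from compound 1 to compound 3 (within the scatter) in this assay for the same shared core. Three different groups at this place therefore read alike, and all three compounds remain low on this scale, so none of these groups separates itself from the others. Nothing at hand gives a reason for these low numbers.

As far as these compounds go, whether the low numbers are tied to this place or to the shared core stays open, since the three compounds differ only here. From the compounds shown here alone, it is also open how an amine, a carboxylic acid or a longer alkyl chain at this place would read in this assay on the same scale.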